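The source may hold more compounds than are shown below. What is called first, only, known or untested is meant among the compounds shown, and "the series" means these compounds.

Compound 2 `CC(C)(C)n1ncc(OCc2nnc(-c3ccccc3)o2)c(Cl)c1=O` gives 2.95 in a physicochemical assay for lipophilicity; on this read-out lower numbers stand for lower lipophilicity and higher numbers for higher lipophilicity. Compound 1 `CC(C)(C)n1ncc(OCc2nnc(-c3ccc(Cl)cc3)o2)c(Cl)c1=O` carries a further substituent, (chloro in place of hydrogen on an aromatic carbon), and in this assay compound 1 gives 3.09, so that the change yields a number 0.14 log units higher from compound 2 to compound 1 (within the scatter). Compound 3 `CC(C)(C)n1ncc(OCc2nnc(-c3ccccc3F)o2)c(Cl)c1=O` differs from compound 2 by fluoro in place of hydrogen on an aromatic carbon; in this assay compound 3 gives 2.89, a shift of a number 0.06 log units lower from compound 2 to compound 3 (within the scatter), while the comparison with compound 1 reads a number 0.20 log units lower from compound 1 to compound 3 (within the scatter). All three results sit within the scatter of one another.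

Compound 4 `CC(C)(C)n1ncc(OCc2nnc(-c3ccc(Cl)cc3F)o2)c(Cl)c1=O` has not yet been measured in this assay. It differs from compound 3 by chloro in place of hydrogen on an aromatic carbon. Among the measured compounds shown here, this is the same kind of change as the one from compound 2 to compound 1, though not the same: the entering chloro now sits meta to a fluoro group as well as para to a large group, whereas on compound 1 it sits only para to a large group. The earlier instance of this change gave a number 0.14 log units higher from compound 2 to compound 1 (within the scatter), and on that basis a step of a number 0.14 log units higher from compound 3 to compound 4 (within the scatter) is expected for compound 4. Compound 4 is therefore estimated at 3.03, with a range from 2.8 to 3.3.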

Compound 4, partition coefficient: 3.23
Beside the measured number, compound 4's estimate is 0.20 log units below it; measured number inside the range.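

In this assay, chloro in place of hydrogen on an aromatic carbon gave a number 0.14 log units higher from compound 2 to compound 1 (within the scatter) and then a number 0.34 log units higher from compound 3 to compound 4 (beyond the scatter), so the change points the same way in both pairs, but only the second step, a modest one, clears the scatter. The other two new steps, a number 0.28 log units higher from compound 2 to compound 4 (within the scatter) and a number 0.14 log units higher from compound 1 to compound 4 (within the scatter), both stay within the scatter, and these two instances of the change, which share one core and differ only by the fluoro group, show neither that the size of the step is fixed nor that it would carry to a different core. No measurement shown here bears on why the two chloro steps fall on different sides of the scatter.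

The compounds shown leave open whether the same chloro step would follow if an amine or a carboxylic acid stood in place of the fluoro group. Among the compounds shown here, they also leave open how the change would behave on any core other than the one all four compounds share.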